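Triazole ester of a terpenoid acid: cytotoxicity notes

The source may report more compounds than this note shows. Statements on the series, on what has been measured and on what is new or still open speak of the compounds shown alone.

Measured so far in an ADME assay on L132 cells (Homo sapiens) for cytotoxicity, read by MTT assay, with a stated time of 48 h; on this read-out higher numbers stand for weaker inhibition and lower numbers for stronger inhibition:
compound 1, `C/C(=C\CC/C(C)=C/CC[C@@H]1[C@@]2(C)CCC(=O)C(C)(C)[C@H]2CC[C@@]1(C)O)CC/C=C(\C)C(=O)OCc1cn(-c2ccccc2Br)nn1`: > 150000 nM.
compound 2, `C/C(=C\CC/C(C)=C/CC[C@@H]1[C@@]2(C)CCC(=O)C(C)(C)[C@H]2CC[C@@]1(C)O)CC/C=C(\C)C(=O)OCc1cn(C[C@@H]2O[C@H](n3ccc(=O)[nH]c3=O)[C@H]3OC(C)(C)O[C@H]32)nn1`: > 150000 nM.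
compound 3, `C/C(=C\CC/C(C)=C/CC[C@@H]1[C@@]2(C)CCC(=O)C(C)(C)[C@H]2CC[C@@]1(C)O)CC/C=C(\C)C(=O)O`: > 150000 nM.

For compound 3 this value is a limit of the assay and not a number. For compound 2 the value is likewise only a limit. For compound 1 the value is again only a limit. Within the data shown here, compound 1 therefore stands where every other compound of the series stands, because of the limit of > 150000 nM in this assay, at which 3 of the 3 values shown sit; no measured value separates any two of these three compounds, and no step between them can be sized.

Compound 4, `C/C(=C\CC/C(C)=C/CC[C@@H]1[C@@]2(C)CCC(=O)C(C)(C)[C@H]2CC[C@@]1(C)O)CC/C=C(\C)C(=O)OCc1cn(-c2ccc(C)cc2)nn1`, is not yet measured. It differs from compound 1 in one place: 4-methylphenyl in place of 2-bromophenyl on an aromatic nitrogen. The ester, the triazole and the shared core of compound 1 are kept unchanged.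

With the three known compounds sitting at the limit, no step beyond the usual scatter is expected from compound 1 to compound 4 in this assay, and the expected step that the limit leaves unreadable from compound 1 to compound 4 is read as none; the likeliest outcome is again a limit rather than a number. The estimate for compound 4 in this assay is 200000 nM, expected between 100000 nM and 600000 nM.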

Compound 4, half-maximal inhibitory concentration: > 150000 nM
Compound 4: no number, only a limit; the forecaster's own chance of this, stated with the estimate: 85%; the middle value is on the limit's open side.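

In this assay compound 4 gives > 150000 nM, which is a limit and not a number. No step from compound 1 to compound 4 can be read, as both compounds stand at a limit: the limit of > 150000 nM in this assay, at which 4 of the 4 values shown sit.

The compounds shown leave open whether any change to the group on the triazole would give a number in this assay.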